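The source may report more compounds than this note shows. Statements on the series, on what has been measured and on what is new or still open speak of the compounds shown alone.

Going by the values given here, in a functional assay on MDA-MB-231 cells (Homo sapiens) for antiproliferative activity, read by CCK-8 assay, with a stated time of 72 h (a lower number here means a stronger inhibitor, a higher number a weaker inhibitor), three compounds sharing one core have numbers so far, and they differ only in the group on a carbonyl carbon. Compound 1 `COc1ccc(C(=O)Nc2ccc(C(=O)/C=C/c3nc(C)c(C)nc3C)cc2)cc1OC`, with 3,4-dimethoxyphenyl there, gives 3360 nM. Compound 2 `COc1cccc(OC)c1C(=O)Nc1ccc(C(=O)/C=C/c2nc(C)c(C)nc2C)cc1`, with 2,6-dimethoxyphenyl, gives 3850 nM, and the step of a 1.1-fold higher number from compound 1 to compound 2 (0.06 log units; within the scatter) does not separate the two. Compound 3 `Cc1nc(C)c(/C=C/C(=O)c2ccc(NC(=O)c3ccccc3)cc2)nc1C`, with phenyl, gives 1840 nM. It cannot be told apart from the first of these, the step being a 1.8-fold lower number from compound 1 to compound 3 (0.26 log units; within the scatter), but it does stand apart from the second, by a modest 2.1-fold lower number from compound 2 to compound 3 (0.32 log units; beyond the scatter).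

Compound 4 `Cc1nc(C)c(/C=C/C(=O)c2ccc(NC(=O)c3ccc(F)cc3F)cc2)nc1C` departs from compound 3 at that same place: 2,4-difluorophenyl in place of phenyl on a carbonyl carbon. Among the compounds with values here, only the steps above bear on this change, and they bear on it loosely, since no compound with fluorine has been measured. Even so, all three replacements at this place moved the number little, the largest being a 2.1-fold lower number from compound 2 to compound 3 (0.32 log units; beyond the scatter). No sizeable shift is therefore expected, and the estimated step, a 1.1-fold lower number from compound 3 to compound 4 (0.03 log units; within the scatter), would lie within the scatter. Compound 4 is expected at about 1700 nM, with an estimated range of 700 nM to 4000 nM.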

Compound 4, half-maximal inhibitory concentration: 1770 nM
Compound 4: the middle estimate sits 1.0-fold (0.02 log units) below what was measured; the measured number falls inside the stated range.
By their numbers in this assay, from the lowest: compounds 4, 3, 1 and 2 (each within the scatter of the next, the first and the last beyond it).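

In this assay, going by these compounds alone, the first fluorine-bearing group at this place leaves the number where it was: 2,4-difluorophenyl cannot be told apart from phenyl on the carbonyl carbon, the step being a 1.0-fold lower number from compound 3 to compound 4 (0.02 log units; within the scatter). The new group also repeats the pattern of phenyl against the two dimethoxyphenyl groups, with a modest separation from 2,6-dimethoxyphenyl, a 2.2-fold lower number from compound 2 to compound 4 (0.34 log units; beyond the scatter), and none from 3,4-dimethoxyphenyl, a 1.9-fold lower number from compound 1 to compound 4 (0.28 log units; within the scatter). So four aryl groups now sit on this carbonyl carbon with only small differences among them, and no measurement at hand accounts for the absence of a shift between phenyl and 2,4-difluorophenyl.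

The compounds shown leave open whether this tolerance extends beyond phenyl rings bearing methoxy or fluorine, for instance to a phenyl carrying an amine or a carboxylic acid, or to a longer alkyl chain on the carbonyl carbon. They also leave open whether any group at this place can move the number by more than these small steps, or whether changes elsewhere in the shared core would be needed to do so.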